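Aminophenyl for hydroxyphenyl on the shared core

This account rests on a few compounds, and the source may have more. Where it says the series, first, only, none or still open, it means among the compounds named here.

Compound 1 `Oc1ccc(C2CC(c3ccccc3)=NN2c2ccc(Cl)cc2)cc1`: 31.6%
Compound 2 `Oc1ccc(C2CC(c3ccccc3O)=NN2c2ccc(Cl)cc2)cc1`: 13.4%

In an assay on isolated protein for inhibition of protein kinase C iota type (Homo sapiens), tested at 20 uM (a higher number here means more inhibition at the concentration tested (going by the name of the read-out), a lower number less inhibition), compound 2 stands lowest of the two numbers shown, with compound 1 nearest and higher by a number 18.2 percentage points lower from compound 1 to compound 2 (beyond the scatter). Compound 3 `Nc1ccc(C2=NN(c3ccc(Cl)cc3)C(c3ccc(O)cc3)C2)cc1` differs from compound 2 by 4-aminophenyl in place of 2-hydroxyphenyl on a carbon with a double bond to nitrogen. Among the measured compounds shown here, the single measured step bears on this only loosely: it shows what adding a hydroxy on an aromatic carbon did, not what an amino does, so a modest rise in this assay is expected, roughly reversing part of that step. Compound 3 is therefore estimated at 25% (range 5% to 45%), a step of a number 11.6 percentage points higher from compound 2 to compound 3 (beyond the scatter).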

Compound 3, a percentage reported as inhibition, at one concentration (the size of the read-out at that concentration, not a potency): 38.7%
The estimate for compound 3 lay 13.7 percentage points below the measured number; the measured number falls inside the stated range.
By their numbers in this assay, from the lowest: compound 2; then compounds 1 and 3 (each within the scatter of the next).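

In this assay, 4-aminophenyl in place of 2-hydroxyphenyl on this carbon gives a number 25.3 percentage points higher from compound 2 to compound 3 (beyond the scatter), so the drop seen with compound 2 does not follow from every donor-bearing phenyl here. Amino in place of hydrogen gives a number 7.1 percentage points higher from compound 1 to compound 3 (within the scatter), so this substituent leaves compound 3 indistinguishable from compound 1. Nothing available explains either step. Both the group and its ring position differ between compound 2 and compound 3. 4-hydroxyphenyl or 2-aminophenyl would be needed to separate them. From the compounds shown here alone, how a carboxylic acid on this phenyl would read also remains open.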